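The source may hold more compounds than are shown below. What is called first, only, known or untested is meant among the compounds shown, and "the series" means these compounds.

Values in a functional assay on K562 cells (Homo sapiens) for antiproliferative activity, with a stated time of 48 h (a higher number here means a weaker inhibitor of growth, a lower number a stronger inhibitor of growth), so far:
Compound 1 `C=CCOc1ccc(/C=C/C(C)=O)cc1OC` gives 68700 nM
Compound 2 `C#CCOc1ccc(/C=C/C(C)=O)cc1OC` gives > 150000 nM (a limit)
Compound 3 `COc1cc(/C=C/C(C)=O)ccc1OCCCNC(=O)OC(C)(C)C` gives > 150000 nM (a limit)

Compound 2 stands at > 150000 nM and that is a limit, not a number. Compound 4 `COC(=O)COc1ccc(/C=C/C(C)=O)cc1OC` has methoxycarbonyl in place of ethynyl on a saturated chain carbon bound to an oxygen on an aromatic ring while the rest of compound 2 stays. Within the data shown here, one measured step touches this place (an at least 2.1-fold higher number from compound 1 to compound 2 (0.33 log units; beyond the scatter)) and shows that the group there can move the number. Most values rest on one ceiling (the limit of > 150000 nM in this assay, at which 2 of the 3 values shown sit) so the size of any step from there is poorly defined. No step beyond the scatter is expected, and the estimate reads (an at least 1.2-fold lower number from compound 2 to compound 4 (0.09 log units; that floor lies within the scatter)) with another limit quite possible. In this assay compound 4 is expected at 120000 nM with a range from 50000 nM to 200000 nM as an estimate.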

Compound 4, concentration for 50% growth inhibition: > 150000 nM
Compound 4: only a limit was reported; the forecaster's own chance of this, stated with the estimate: 55%; middle value at least 1.2-fold (0.09 log units) from the limit.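

In this assay, exchanging vinyl for methoxycarbonyl gives an at least 2.1-fold higher number from compound 1 to compound 4 (0.33 log units; beyond the scatter), so ethynyl is no longer the only replacement for vinyl shown to give a weaker result. Compound 2 and compound 4 both give limits, and the step between them cannot be read. Only compound 1 gives a true number, and the others stop at a ceiling: the limit of > 150000 nM in this assay, at which 3 of the 4 values shown sit.

From the compounds shown here alone, it remains open whether any group at this place can give stronger growth inhibition than vinyl. A carboxylic acid, an amine or a longer chain ending in a vinyl group could show how far the number can move.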